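A few compounds are considered here, and "the series" means these few. Any claim that something is new, unique, unknown or untested is made for them only; others in the source may bear on it.

Compound 1 `Nc1scc(CN2CCN(c3cc(Cl)cc(Cl)c3)CC2)c1C(=O)c1ccc(Cl)cc1`: -74%
Compound 2 `Nc1scc(CN2CCN(c3ccc(Cl)cc3F)CC2)c1C(=O)c1ccc(Cl)cc1`: -81%
Compound 3 `Nc1scc(CN2CCN(c3cccc(C(F)(F)F)c3)CC2)c1C(=O)c1ccc(Cl)cc1`: -80%

In a functional assay on CHO cells with adenosine receptor A1 (Homo sapiens) as the target, read by cAMP accumulation and immunoassay, with a stated time of 6 min, tested at 10 uM (a lower number here means a stronger effect, a higher number a weaker effect of the compound at the concentration tested), compound 3 gives -80%, the second highest of the three numbers. Its neighbours sit close: the step of a number 1 percentage points higher from compound 2 to compound 3 (within the scatter) and the step of a number 6 percentage points lower from compound 1 to compound 3 (within the scatter) both stay within the scatter. Compound 4 `Nc1scc(CN2CCN(c3ccncc3)CC2)c1C(=O)c1ccc(Cl)cc1` has not yet been measured; it differs from compound 3 by pyridin-4-yl in place of 3-(trifluoromethyl)phenyl on an amine nitrogen in a ring. Going by the values given here, no measured step swaps a phenyl for a pyridinyl, so the three steps that exist bear only loosely on it: a number 7 percentage points lower from compound 1 to compound 2 (within the scatter), a number 6 percentage points lower from compound 1 to compound 3 (within the scatter) and a number 1 percentage points higher from compound 2 to compound 3 (within the scatter) all changed the ring substituents without moving the read-out beyond the scatter. A step of no clear size beyond the scatter is therefore expected, with more room for a weaker effect, as a number 15 percentage points higher from compound 3 to compound 4 (beyond the scatter). Compound 4 is estimated at -65%, ranging from -90% to -25%.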

Compound 4, a percentage reported as activity, at one concentration (the size of the read-out at that concentration, not a potency): -15%
Compound 4: the middle estimate sits 50 percentage points below what was measured; the whole stated range lies below it.
By their numbers in this assay, from the lowest: compounds 2, 3 and 1 (each within the scatter of the next); then compound 4.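

In this assay replacing any of the three substituted phenyl groups with pyridin-4-yl weakens the effect sharply, with a number 65 percentage points higher from compound 3 to compound 4 (beyond the scatter) and a number 66 percentage points higher from compound 2 to compound 4 (beyond the scatter) and a number 59 percentage points higher from compound 1 to compound 4 (beyond the scatter) all pointing the same way. The earlier swaps among carbon-only rings stayed within the scatter, so this position does not accept every six-membered aromatic ring. Nothing measured here says why the effect falls. The compounds shown leave open whether a plain phenyl or a pyridin-3-yl would keep the effect, so the ring nitrogen cannot be separated from the loss of the chlorine, fluorine or trifluoromethyl substituents.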